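A methoxy-to-hydroxy change in a cytotoxicity series

This account rests on a few compounds, and the source may have more. Where it says the series, first, only, none or still open, it means among the compounds named here.

Measured so far:
compound 1 `Cc1cc(O)cc(-c2nn(CC#N)cc2-c2ccnc(-c3ccc(Oc4ccccc4)cc3)c2)c1`: 94%
compound 2 `COc1cc(C)cc(-c2nn(CC#N)cc2-c2ccnc(-c3ccc(N(C)C)cc3)c2)c1`: 89%

In a functional assay on KM12 cells (Homo sapiens) for cytotoxicity, read by sulforhodamine B assay, with a stated time of 48 h, tested at 0.01 uM (a lower number here means a stronger effect, a higher number a weaker effect of the compound at the concentration tested), compound 1 gives 94% and compound 2 gives 89%. Compound 2 has the lower of the two numbers, though its gap to compound 1 lies within the scatter, so no real difference between them can be claimed. Compound 3 `Cc1cc(O)cc(-c2nn(CC#N)cc2-c2ccnc(-c3ccc(N(C)C)cc3)c2)c1` has not yet been measured. It differs from compound 2 by hydrogen in place of methyl on an oxygen on an aromatic ring. Among the measured compounds shown here, no step between measured compounds covers this change, so only a small step, in no firm direction and not beyond the scatter, is expected: a number 1 percentage points higher from compound 2 to compound 3 (within the scatter). Compound 3 is estimated at 90%, with a range from 75% to 100%.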

Compound 3, a percentage reported as activity, at one concentration (the size of the read-out at that concentration, not a potency): 76%
Estimate against measurement, compound 3: 14 percentage points above; low and high end bracket the measured number.
By their numbers in this assay, from the lowest: compound 3; then compounds 2 and 1 (each within the scatter of the next).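

In this assay, among the compounds shown here, methoxy to hydroxy on the aromatic ring gives a number 13 percentage points lower from compound 2 to compound 3 (beyond the scatter) and is the first change here to move the read-out beyond the scatter, so this small change at the oxygen can matter. The other end of the molecule counts too: with the hydroxy kept, dimethylamino in place of phenoxy on an aromatic carbon gives a number 18 percentage points lower from compound 1 to compound 3 (beyond the scatter) as well.

Going by these compounds, whether an ethoxy group, with its longer chain on that oxygen, or an amine in place of the hydroxy would give a similar number remains open. Nothing at hand gives a reason for either step.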